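Ethyl to isopropyl on the amide of compound 3

The source may report more compounds than this note shows. Statements on the series, on what has been measured and on what is new or still open speak of the compounds shown alone.

In a functional assay for antagonist activity at C-X-C chemokine receptor type 3 (Homo sapiens) (a lower number here means a stronger inhibitor, a higher number a weaker inhibitor), compound 1 `CC(=O)c1cnc(N2CCN(C3CCN(Cc4ccc(Cl)cc4)CC3)[C@@H](C)C2)c(Cl)c1` gives 520 nM, compound 2 `CCNC(=N)c1cnc(N2CCN(C3CCN(Cc4ccc(Cl)cc4)CC3)[C@@H](C)C2)c(Cl)c1` gives 83 nM, and compound 3 `CCNC(=O)c1cnc(N2CCN(C3CCN(Cc4ccc(Cl)cc4)CC3)[C@@H](C)C2)c(Cl)c1` gives 2.3 nM, the lowest number of the three. The steps of a 230-fold lower number from compound 1 to compound 3 (2.35 log units; beyond the scatter) and a 36-fold lower number from compound 2 to compound 3 (1.56 log units; beyond the scatter) are both large, while a 6.3-fold lower number from compound 1 to compound 2 (0.80 log units; beyond the scatter) is modest. Compound 4 `CC(C)NC(=O)c1cnc(N2CCN(C3CCN(Cc4ccc(Cl)cc4)CC3)[C@@H](C)C2)c(Cl)c1` differs from compound 3 by methyl in place of hydrogen on a saturated chain carbon bound to an amide-type nitrogen and a saturated chain carbon. Among the measured compounds shown here, no measured step touches the alkyl on the amide nitrogen; the large steps concern the whole group on the aromatic carbon, which compound 4 keeps. The account therefore expects for compound 4 a step of a 1.5-fold higher number from compound 3 to compound 4 (0.18 log units; within the scatter) in this assay, not beyond the scatter. Compound 4 is estimated at 3.5 nM, with a range from 1 nM to 12 nM.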

Compound 4, half-maximal inhibitory concentration: 5 nM
Compound 4: middle estimate off by 1.4-fold (0.15 log units), on the low side; the measured number falls inside the stated range.
By their numbers in this assay, from the lowest: compound 3; then compound 4; then compound 2; then compound 1.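

In this assay the alkyl on the amide nitrogen proves not to be silent: ethyl to isopropyl gives a 2.2-fold higher number from compound 3 to compound 4 (0.34 log units; beyond the scatter) as a modest step, the first measured at this position. The isopropylcarbamoyl group still stands well ahead of the other groups on the aromatic carbon, with a 17-fold lower number from compound 2 to compound 4 (1.22 log units; beyond the scatter) and a 100-fold lower number from compound 1 to compound 4 (2.02 log units; beyond the scatter) both large. Nothing measured here explains the step from ethyl to isopropyl. The compounds shown leave open how a longer chain such as propyl, or a cyclopropyl or tert-butyl group, on the amide nitrogen would compare. They also leave open what a methyl group in place of the amide hydrogen would do.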